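This account rests on a few compounds, and the source may have more. Where it says the series, first, only, none or still open, it means among the compounds named here.

Compound 1 `N/C(=N\NC(=S)N1CCCCCC1)c1ccccn1` and compound 2 `N/C(=N\NC(=S)N1CCCCC1)c1ccccn1` share the same kind of thiosemicarbazone arrangement but differ in their ring-containing portion; the difference between the two cores is not broken down here. In a functional assay on A-375 cells (Homo sapiens) for cytotoxicity, read by MTT assay, with a stated time of 72 h, tested at 3 uM (a higher number here means more inhibition of growth at the concentration tested, a lower number less inhibition of growth), compound 1 gives 78.6%, and in this assay compound 2 gives 86.5%, two numbers that lie within the usual scatter of each other. Compound 3 `Cc1cccc(/C(N)=N/NC(=S)N2CCCCCC2)n1` carries a methyl in place of hydrogen on an aromatic carbon relative to compound 1, and in this assay compound 3 gives 64.5%, so that a number 14.1 percentage points lower from compound 1 to compound 3 (beyond the scatter).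

Compound 4 `Cc1ccnc(/C(N)=N/NC(=S)N2CCCCC2)c1` is not yet measured. Among the measured compounds shown here, it carries a methyl in place of hydrogen on an aromatic carbon relative to compound 2, the same kind of change as the one from compound 1 to compound 3, though the methyl now sits opposite the ring nitrogen rather than next to it. Because a number 14.1 percentage points lower from compound 1 to compound 3 (beyond the scatter), a step of roughly similar size is expected here, a number 11.5 percentage points lower from compound 2 to compound 4 (beyond the scatter), with some allowance for the different placement. Compound 4 is therefore estimated to reach 75% in this assay, likely between 62% and 88%.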

Compound 4, percent growth inhibition at one concentration: 69.5%
The estimate for compound 4 lay 5.5 percentage points above the measured number; the range from low to high includes it.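

In this assay, a methyl in place of hydrogen on an aromatic carbon again goes with less inhibition of growth on the second core, with a number 17 percentage points lower from compound 2 to compound 4 (beyond the scatter). Set beside the earlier step, the two changes agree in direction and in size: the same change on two cores in this assay, a number 14.1 percentage points lower (beyond the scatter) from compound 1 to compound 3 and a number 17 percentage points lower (beyond the scatter) from compound 2 to compound 4, 2.9 percentage points apart, within the scatter of two such steps. For these two pairs, then, the change carries over from one core to the other, even with the methyl opposite the ring nitrogen in compound 4, but this does not show why the number falls, does not extend to other cores, and does not separate the role of the core from that of the methyl's place, with each core shown carrying the methyl in one place only.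

The compounds shown leave open whether the methyl in one and the same place on both cores would give steps of this size. They also leave open whether a larger or different group on that aromatic carbon, such as an ethyl, a methoxy or a chlorine, would go the same way.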